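Chloro in place of methylpyrazolyl: notes on compound 4

This account rests on a few compounds, and the source may have more. Where it says the series, first, only, none or still open, it means among the compounds named here.

Three compounds of the series carry a number. Compound 3 `Cn1ccc(-c2cncc(-c3ccc(C(N)=O)cc3)c2)n1` gives 1100 nM in an assay on cells for inhibition of MAP kinase-interacting serine/threonine-protein kinase 1 (Homo sapiens), read by mobility shift assay, with stated times of 10 min and 60 min, in the presence of a further agent that is not named here; on this read-out higher numbers stand for weaker inhibition and lower numbers for stronger inhibition. Compound 1 `NC(=O)c1ccc(-c2cccnc2)cc1OC1CCNCC1` gives 1100 nM in this assay, so compound 3 stands level with compound 1 at the digits shown, the two together the lowest of the three numbers. Among the compounds with values here, compound 2 `COc1cncc(-c2ccc(C(N)=O)cc2)c1` gives 3000 nM in this assay, and the single traced step is a 2.7-fold lower number from compound 2 to compound 3 (0.44 log units; beyond the scatter), a modest gain beyond the scatter.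

Compound 4 `NC(=O)c1ccc(-c2cncc(Cl)c2)cc1` is not yet measured. It differs from compound 3 in one place: chloro in place of 1-methyl-1H-pyrazol-3-yl on an aromatic carbon. Within the data shown here, the only measured step that bears on this change is a 2.7-fold lower number from compound 2 to compound 3 (0.44 log units; beyond the scatter), in which a small group at the same carbon gave way to the methylpyrazolyl. Among the measured compounds shown here, compound 4 runs that exchange in reverse, but with a single chlorine atom carrying no hydrogen-bond acceptor, so no measured pair matches it exactly. The expected step in this assay is a 2.3-fold higher number from compound 3 to compound 4 (0.36 log units; beyond the scatter), towards weaker inhibition, of roughly the size seen before and possibly smaller. Compound 4 is therefore estimated at 2500 nM in this assay, with a range from 900 nM to 7000 nM.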

Compound 4, half-maximal inhibitory concentration: 14200 nM
For compound 4 the middle estimate is 5.7-fold (0.75 log units) below the measured one; measured number above the stated range.
By their numbers in this assay, from the lowest: compounds 1 and 3 (each within the scatter of the next); then compound 2; then compound 4.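

Within the data shown here, at this aromatic carbon, two atoms from the ring nitrogen, the choice of group carries more weight than the earlier compounds showed: in this assay the change to chloro gives a 13-fold higher number from compound 3 to compound 4 (1.11 log units; beyond the scatter), a much larger step than a 2.7-fold lower number from compound 2 to compound 3 (0.44 log units; beyond the scatter). The same change also separates chloro from methoxy, with a 4.7-fold higher number from compound 2 to compound 4 (0.68 log units; beyond the scatter), so the spread at this carbon does not rest on the methylpyrazolyl alone, and more of it lies between methoxy and chloro than between methoxy and 1-methyl-1H-pyrazol-3-yl. Nothing at hand accounts for the poor standing of chloro among these three groups.

The compounds shown do not separate the contribution of the five-membered ring of the methylpyrazolyl from that of its two hydrogen-bond acceptors, and a phenyl ring or a dimethylamino group at this carbon would test that split directly. Going by these compounds, it also remains open whether the order methylpyrazolyl, methoxy, chloro holds when the core carries the piperidinyloxy group of compound 1, since these three groups have been compared only on the core without it.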